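The source may hold more compounds than are shown below. What is called first, only, known or untested is meant among the compounds shown, and "the series" means these compounds.

Measured in a functional assay on CCRF-CEM cells (Homo sapiens) for cytotoxicity, read by XTT assay, with a stated time of 3 days; a lower number here means a stronger inhibitor, a higher number a weaker inhibitor:
- Compound 1 `OC[C@H]1O[C@@H](n2cc(F)c3c(-c4ccco4)ncnc32)[C@H](O)[C@@H]1O`: 1400 nM
- Compound 2 `OC[C@H]1O[C@@H](n2cc(F)c3c(-c4nccs4)ncnc32)[C@H](O)[C@@H]1O`: 550 nM

Of these two compounds, compound 2 has the lower number and is the stronger inhibitor in this assay. The next compound, compound 3 `OC[C@H]1O[C@@H](n2cc(F)c3c(-c4ccc[nH]4)ncnc32)[C@H](O)[C@@H]1O`, keeps the shared core and carries 1H-pyrrol-2-yl in place of 1,3-thiazol-2-yl on an aromatic carbon.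

Among the measured compounds shown here, only one measured step bears on this change. It is a 2.5-fold lower number from compound 1 to compound 2 (0.41 log units; beyond the scatter), a modest step made by putting 1,3-thiazol-2-yl in place of furan-2-yl at the same place. For the measured compounds named here, no measured compound carries 1H-pyrrol-2-yl, so the data do not fix a direction for the new exchange. A step of about that modest size could go either way, and the best single expectation is no step beyond the scatter.

The estimate for the change is a 1.1-fold lower number from compound 2 to compound 3 (0.04 log units; within the scatter), and this remains an expectation with wide uncertainty. For compound 3, the expected value is 500 nM, with an estimated range from 130 nM to 2000 nM.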

Compound 3, half-maximal inhibitory concentration: 410 nM
Beside the measured number, compound 3's estimate is 1.2-fold (0.09 log units) above it, within the range that was stated.
By their numbers in this assay, from the lowest: compounds 3 and 2 (each within the scatter of the next); then compound 1.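

In this assay, putting 1H-pyrrol-2-yl in place of 1,3-thiazol-2-yl on this aromatic carbon gives (a 1.3-fold lower number from compound 2 to compound 3 (0.13 log units; within the scatter)), so these two groups cannot be told apart here, even though they differ in their ring hetero atoms and in their counts of hydrogen-bond donors and acceptors. Putting the same group in place of furan-2-yl gives (a 3.4-fold lower number from compound 1 to compound 3 (0.53 log units; beyond the scatter)), which means that among these three compounds both exchanges away from furan-2-yl move beyond the scatter, and compound 1 is the weakest of the set. No measurement shown here accounts for this ordering.

The compounds shown leave open how far this tolerance extends, since all three groups at this position are five-membered aromatic rings, and a six-membered ring such as pyridin-2-yl or an open group such as an amine or a short alkyl chain would test it beyond that family. They also leave open whether the hydrogen on the pyrrole nitrogen matters to the number, which an N-methylpyrrol-2-yl group at the same place would address.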